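This account rests on a few compounds, and the source may have more. Where it says the series, first, only, none or still open, it means among the compounds named here.

For the measured compounds named here, compound 2 `N#C/C(=C\c1ccc(Cl)cc1)C(=O)NCc1ccc(Cl)c(Cl)c1` is the only compound for which a functional assay on A2780 cells (Homo sapiens) for inhibition, read by MTT assay, with a stated time of 72 h (a lower number here means a stronger inhibitor of growth, a higher number a weaker inhibitor of growth), gives a number, 32000 nM. Compound 1 `N#C/C(=C\c1ccco1)C(=O)NCc1ccc(Cl)c(Cl)c1` gives in this assay > 50000 nM, which is a limit of the assay and not a number. Going by the values given here, the one measured step, an at least 1.5-fold lower number from compound 1 to compound 2 (0.19 log units; that floor lies within the scatter), puts 4-chlorophenyl in place of furan-2-yl on a double-bonded chain carbon bound to a double-bonded chain carbon, and its size rests on (the limit of > 50000 nM in this assay, at which 1 of the 2 values shown sits). Compound 3 `COc1ccc(/C=C(\C#N)C(=O)NCc2ccc(Cl)c(Cl)c2)cc1` differs from compound 2 by methoxy in place of chloro on an aromatic carbon. Among the compounds with values here, no measured step exchanges a group on that aromatic ring, and the single step that was measured stayed within the scatter, so no change beyond the scatter is expected in this assay from this exchange. Compound 3 is therefore expected at 40000 nM, between 15000 nM and 100000 nM. The expected step is a 1.3-fold higher number from compound 2 to compound 3 (0.10 log units; within the scatter).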

Compound 3, concentration for 50% growth inhibition: 86000 nM
The estimate for compound 3 lay 2.2-fold (0.33 log units) below the measured number, and the stated range covers the measured number.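

In this assay, for the compounds shown here, the exchange on the aromatic carbon para to a large group gives the first step here that is beyond the scatter: a 2.7-fold higher number from compound 2 to compound 3 (0.43 log units; beyond the scatter). The group at this place therefore matters for this pair, with the 4-chlorophenyl compound giving the lower number and the 4-methoxyphenyl compound the higher, a difference that the floor of the earlier step from furan-2-yl to 4-chlorophenyl could not establish. The step between compound 1 and compound 3 cannot be read, because compound 1 stands at a limit of the assay and not at a number: the limit of > 50000 nM in this assay, at which 1 of the 3 values shown sits.

From the compounds shown here alone, what an amine, a hydroxy group or a bromo group on the same carbon would give remains open. So does whether the higher number with methoxy would persist if the rest of compound 2 were changed.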